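The source may report more compounds than this note shows. Statements on the series, on what has been measured and on what is new or still open speak of the compounds shown alone.

In an ADME assay on HPLF cells (Homo sapiens) for cytotoxicity, with a stated time of 24 h (a higher number here means that more compound is tolerated, a lower number that less compound is tolerated), compound 1 `O=C1/C(=C/c2ccccc2)CCC/C1=C\c1cccc([N+](=O)[O-])c1` gives 18000 nM. Compound 2 `CN(C)c1ccc(/C=C2\CCC/C(=C\c3cccc([N+](=O)[O-])c3)C2=O)cc1` gives > 400000 nM, which is a limit of the assay and not a number. Its true position is therefore unknown, and only this limit can be stated for it.

Compound 3 `Cc1ccc(/C=C2\CCC/C(=C\c3cccc([N+](=O)[O-])c3)C2=O)cc1` changes one place in compound 2, with methyl in place of dimethylamino on an aromatic carbon, para to a large group: methyl in place of dimethylamino on an aromatic carbon.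

Going by the values given here, one measured step bears on this change. It is an at least 22-fold higher number from compound 1 to compound 2 (1.34 log units; beyond the scatter), a large step beyond the scatter, made by dimethylamino in place of hydrogen on an aromatic carbon. Compound 3 loses that same dimethylamino, so the number is expected to fall back much of the way towards compound 1 at 18000 nM. Among the compounds with values here, no methyl compound has been measured yet, and a single step is thin ground, so the range must stay wide. In this assay a large drop is expected, estimated as an at least 11-fold lower number from compound 2 to compound 3 (1.05 log units; beyond the scatter). The estimated value for compound 3 is 35000 nM, with an expected range of 10000 nM to 150000 nM.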

Compound 3, half-maximal cytotoxic concentration: > 400000 nM
Compound 3 gave a limit, no number; the forecaster's own chance of this, stated with the estimate: 10%; middle value at least 11-fold (1.05 log units) from the limit.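

In this assay, methyl in place of hydrogen on the aromatic carbon gives an at least 22-fold higher number from compound 1 to compound 3 (1.34 log units; beyond the scatter), so the large rise seen earlier does not need dimethylamino: a group as small as methyl at this place, para to a large group, is enough. The step from compound 2 to compound 3 cannot be read, because each of these compounds stands at a limit of the assay and not at a number: the limit of > 400000 nM in this assay, at which 2 of the 3 values shown sit.

Dimethylamino and methyl therefore cannot be ranked against each other, and the only firm statement is that both separate their compounds clearly from compound 1 at 18000 nM.

Going by these compounds, how much of either compound the cells would truly tolerate stays unknown, since the real values could lie close together or far apart. Also open, on these data alone, is whether the rise extends to other groups on the same carbon, such as a methoxy group, a chlorine atom or a carboxylic acid, or whether some of these would leave the number near that of compound 1.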